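This account rests on a few compounds, and the source may have more. Where it says the series, first, only, none or still open, it means among the compounds named here.

In a functional assay on HT-29 cells (Homo sapiens) for inhibition, read by CCK-8 assay, with a stated time of 24 h (a lower number here means a stronger inhibitor, a higher number a weaker inhibitor), compound 1 `O=C1Nc2ccccc2/C1=C/c1ccc(-c2cn(-c3ccccc3Cl)nn2)cc1` reaches only the limit of the assay, > 20000 nM. Compound 2 `N#Cc1ccccc1-n1cc(-c2ccc(/C=C3\C(=O)Nc4ccccc43)cc2)nn1` gives 14400 nM in this assay. The change between them is cyano in place of chloro on an aromatic carbon, and it brought an at least 1.3-fold lower number from compound 1 to compound 2 (0.14 log units; that floor lies within the scatter); that step is known only as a floor due to the limit of > 20000 nM in this assay, at which 1 of the 3 values shown sits. Compound 3 `O=C1Nc2ccc(F)cc2/C1=C/c1ccc(-c2cn(-c3cccc(Cl)c3)nn2)cc1` gives 10500 nM in this assay. Compound 3 and compound 1 differ in more than one place, and the difference between the two cores is not broken down here.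

Compound 4 `N#Cc1cccc(-n2cc(-c3ccc(/C=C4\C(=O)Nc5ccc(F)cc54)cc3)nn2)c1` has not yet been measured. It differs from compound 3 by cyano in place of chloro on an aromatic carbon. For the measured compounds named here, this is the same kind of change as the one from compound 1 to compound 2, though not the same: in compound 1 the chloro sits ortho to a large group, in compound 3 it sits meta to a large group. An expected step of a 1.3-fold lower number from compound 3 to compound 4 (0.12 log units; within the scatter) rests on an at least 1.3-fold lower number from compound 1 to compound 2 (0.14 log units; that floor lies within the scatter), a floor that lies within the scatter. Compound 4 is therefore estimated at 8000 nM, with a likely range from 4000 nM to 16000 nM.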

Compound 4, half-maximal inhibitory concentration: > 20000 nM
Compound 4 gave a limit, no number (the forecaster's own chance of this, stated with the estimate: 5%); at least 2.5-fold (0.39 log units) between middle value and limit.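

In this assay compound 4 reaches only a limit of the assay, > 20000 nM, which is a limit and not a number. On the core of compound 3, placing cyano where chloro stood gave an at least 1.9-fold higher number from compound 3 to compound 4 (0.27 log units; that floor lies within the scatter), so the slightly lower number expected from the earlier pair did not appear, though this floor alone does not establish a real rise. Neither does the comparison show that the change behaves differently on the two cores, or that it carries over unchanged from one to the other: the same change on two cores in this assay, an at least 1.3-fold lower number (0.14 log units; that floor lies within the scatter) from compound 1 to compound 2 and an at least 1.9-fold higher number (0.27 log units; that floor lies within the scatter) from compound 3 to compound 4; the limit leaves it open whether they differ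

From the compounds shown here alone, the chloro also sits in a different place in compound 1 and compound 3, so what this change does at one fixed place on a single core remains open. Also open, going by these compounds, is how an amine or a carboxylic acid on that same aromatic carbon would read in this assay.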